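Fluoro for methoxy on the pendant phenyl of compound 3

The source may report more compounds than this note shows. Statements on the series, on what has been measured and on what is new or still open speak of the compounds shown alone.

Measured compounds:
compound 1 `Brc1cn2ccnc2c(-c2ccc3ncn(C4CCCCC4)c3c2)n1`: 44.4%
compound 2 `c1ccc(-c2cn3ccnc3c(-c3ccc4ncn(C5CCCCC5)c4c3)n2)cc1`: 54.4%
compound 3 `COc1ccccc1-c1cn2ccnc2c(-c2ccc3ncn(C4CCCCC4)c3c2)n1`: 14.6%

Three compounds sharing one core were tested in a functional assay on MDA-MB-468 cells (Homo sapiens) for inhibition, read by sulforhodamine B assay, with a stated time of 48 h, tested at 10 uM; on this read-out lower numbers stand for less inhibition and higher numbers for more inhibition at the one concentration tested (going by the name of the read-out). Compound 1 gives 44.4% in this assay, compound 2 gives 54.4% and compound 3 gives 14.6%, the lowest of the three numbers. The step of a number 10 percentage points higher from compound 1 to compound 2 (within the scatter) stays within the scatter, while a number 29.8 percentage points lower from compound 1 to compound 3 (beyond the scatter) and a number 39.8 percentage points lower from compound 2 to compound 3 (beyond the scatter) both lie beyond it, so compound 3 stands clearly apart from the other two.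

Compound 4 `Fc1ccccc1-c1cn2ccnc2c(-c2ccc3ncn(C4CCCCC4)c3c2)n1` has not yet been measured. It differs from compound 3 in one place: fluoro in place of methoxy on an aromatic carbon. Of the measured steps, the one that bears most directly on this change is a number 39.8 percentage points lower from compound 2 to compound 3 (beyond the scatter), since compound 4 keeps a substituent on that carbon but no longer the methoxy; a number 29.8 percentage points lower from compound 1 to compound 3 (beyond the scatter) points the same way. Among the compounds with values here, no measured pair contains a fluoro group, so the size of the return is not fixed by the data. Compound 4 is therefore expected to recover part of the loss, with an estimated step of a number 20.4 percentage points higher from compound 3 to compound 4 (beyond the scatter) in this assay. The estimate for compound 4 is 35%, in a range from 10% to 60%.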

Compound 4, a percentage reported as inhibition, at one concentration (the size of the read-out at that concentration, not a potency): 27.6%
For compound 4 the middle estimate is 7.4 percentage points above the measured one; low and high end bracket the measured number.
By their numbers in this assay, from the lowest: compound 3; then compound 4; then compounds 1 and 2 (each within the scatter of the next).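

In this assay, the change from 2-methoxyphenyl to 2-fluorophenyl gives a number 13 percentage points higher from compound 3 to compound 4 (beyond the scatter), so the low number of compound 3 belongs to the methoxy rather than to every group on this aromatic carbon ortho to a large group. The fluoro does not bring the number back to that of the unsubstituted phenyl, however: the reading is a number 26.8 percentage points lower from compound 2 to compound 4 (beyond the scatter), and against the bromo compound it is a number 16.8 percentage points lower from compound 1 to compound 4 (beyond the scatter), so both substituted phenyls, with none of the compounds shown going against this, read lower than compound 1 and compound 2. No measurement bears on why the methoxy and the fluoro differ, or why either reads below hydrogen.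

The compounds shown leave open how a methyl, a chlorine, a hydroxy or an amine on this same carbon would read, and whether any group there could match the unsubstituted phenyl of compound 2. As far as these compounds go, all four compounds also share the rest of the core, and each was read at a single concentration, so whether these steps hold with other groups on that core, or at other concentrations, remains unknown.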